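Nitro-to-fluoro swap on an anilinoquinazoline series

The compounds below may be only part of what the source reports. "The series", "measured", "known", "first", "only" and "open" are said of these compounds alone.

compound 1, `COc1cc2ncnc(Nc3ccc([N+](=O)[O-])cc3)c2c(OC)c1OC`: 24.9% in a functional assay on PC-3 cells (Homo sapiens) for inhibition, read by MTT assay, with a stated time of 72 h, tested at 10 uM; on this read-out higher numbers stand for more inhibition of growth at the one concentration tested and lower numbers for less inhibition of growth
compound 2, `COc1cc2ncnc(Nc3ccc(F)cc3)c2c(OC)c1OC`: 9.1% in this assay
compound 3, `COc1cc2ncnc(Nc3ccccc3[N+](=O)[O-])c2c(OC)c1OC`: 25.5% in this assay

Compound 4, `COc1cc2ncnc(Nc3ccccc3F)c2c(OC)c1OC`, is not yet measured. It differs from compound 3 by fluoro in place of nitro on an aromatic carbon. The same kind of change, (fluoro in place of nitro on an aromatic carbon), has already been measured once, and there it gave a number 15.8 percentage points lower from compound 1 to compound 2 (beyond the scatter). The two places are not the same: in the measured pair the group sits para to a large group, in the new pair ortho to a large group. How the cores of compound 1 and compound 3 differ is not broken down here; their values in this assay lie within the scatter of each other. Going by the values given here, since compound 3 starts close to compound 1, a step of about the same size is expected, a number 15.5 percentage points lower from compound 3 to compound 4 (beyond the scatter), because a number 15.8 percentage points lower from compound 1 to compound 2 (beyond the scatter) is the only measured guide. Compound 4 is therefore estimated at 10%, between 0% and 22%.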

Compound 4, percent growth inhibition at one concentration: 24%
Compound 4: middle estimate off by 14 percentage points, on the low side; the whole stated range lies below it.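

Replacing nitro with fluoro does not give the same result on the two cores in this assay: the same change on two cores in this assay, a number 15.8 percentage points lower (beyond the scatter) from compound 1 to compound 2 and a number 1.5 percentage points lower (within the scatter) from compound 3 to compound 4, 14.3 percentage points apart, beyond the scatter of two such steps. For the newly measured pair, fluoro in place of nitro gives a number 1.5 percentage points lower from compound 3 to compound 4 (within the scatter). The two fluoro compounds also separate, since 2-fluorophenyl in place of 4-fluorophenyl gives a number 14.9 percentage points higher from compound 2 to compound 4 (beyond the scatter), whereas the two nitro compounds lie within the scatter of each other. This shows that a step measured on one core does not fix the size of the same change on another core, but two pairs cannot give a general rule or explain why the steps differ.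

The compounds shown leave open how an amine or a carboxylic acid in place of nitro would read on either core. They also leave open whether these steps hold at other concentrations.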